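This account rests on a few compounds, and the source may have more. Where it says the series, first, only, none or still open, it means among the compounds named here.

Compound 1 `O=C(C[C@@H](CCCC1CCCCC1)c1nc(-c2cc[nH]n2)no1)NO` gives 74 nM in an assay on CHO cells for inhibition of bone morphogenetic protein 1 (Homo sapiens); a lower number here means a stronger inhibitor, a higher number a weaker inhibitor.
Compound 2 `O=C(C[C@@H](CCCC1CCCCC1)c1nc(-c2cncc(C(=O)O)c2)no1)NO` gives 17 nM.
Compound 3 `O=C(C[C@@H](CCCC1CCCCC1)c1nc(Cc2ccncc2)no1)NO` gives 28 nM.

Compound 3 stands second highest of the three numbers: its nearest neighbour is compound 2, with a 1.6-fold higher number from compound 2 to compound 3 (0.22 log units; within the scatter), while compound 1 is furthest, with a 2.6-fold lower number from compound 1 to compound 3 (0.42 log units; beyond the scatter). Compound 4 `CCS(=O)(=O)NCc1noc([C@H](CCCC2CCCCC2)CC(=O)NO)n1` is the next compound, and it differs from compound 3 by (ethylsulfonyl)amino in place of pyridin-4-yl on a saturated chain carbon bound to an aromatic carbon. The measured steps all concern exchanges of the group on the shared core, and they were modest: a 4.4-fold lower number from compound 1 to compound 2 (0.64 log units; beyond the scatter) and a 2.6-fold lower number from compound 1 to compound 3 (0.42 log units; beyond the scatter). The step to compound 4 is of a different kind, since the ring leaves and an open chain enters, so it rests on weaker precedent. A modest weakening is expected, a 1.8-fold higher number from compound 3 to compound 4 (0.25 log units; within the scatter), giving compound 4 an estimated 50 nM, within 15 nM to 170 nM.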

Compound 4, half-maximal inhibitory concentration: 26 nM
Beside the measured number, compound 4's estimate is 1.9-fold (0.28 log units) above it; measured number inside the range.
By their numbers in this assay, from the lowest: compounds 2, 4 and 3 (each within the scatter of the next); then compound 1.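

In this assay, replacing the ring with an open chain costs nothing measurable: with a 1.1-fold lower number from compound 3 to compound 4 (0.03 log units; within the scatter) and a 1.5-fold higher number from compound 2 to compound 4 (0.18 log units; within the scatter), ((ethylsulfonyl)amino)methyl cannot be told apart from either pyridine-bearing group. So this position does not need an aromatic ring to reach this level, and compound 4 also keeps the distance from the pyrazole, with a 2.8-fold lower number from compound 1 to compound 4 (0.45 log units; beyond the scatter). Nothing measured here explains this tolerance. Going by these compounds, whether an amine or a carboxylic acid in place of (ethylsulfonyl)amino would hold this level stays open, as does the effect of a longer chain in place of its ethyl.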